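This account rests on a few compounds, and the source may have more. Where it says the series, first, only, none or still open, it means among the compounds named here.

Compound 1 (`Cc1cnc(Nc2ccc(C(C)C)cc2)nc1Nc1nc2ccccc2s1`) is the starting point of this comparison, and in a functional assay on PC-3 cells (Homo sapiens) for antiproliferative activity, read by MTT assay, with a stated time of 48 h (a lower number here means a stronger inhibitor, a higher number a weaker inhibitor), compound 1 gives only a limit, > 50000 nM, rather than a number. That limit is where compound 1 stands on the evidence available: the limit of > 50000 nM in this assay, at which 1 of the 3 values shown sits. Two related compounds carry a sulfonyl-bearing aniline instead. Compound 2 (`CS(=O)(=O)c1ccc(Nc2nccc(Nc3nc4ccc(F)cc4s3)n2)cc1`) gives 1940 nM in this assay, and compound 3 (`NS(=O)(=O)c1ccc(Nc2ncc(F)c(Nc3nc4ccc(Cl)cc4s3)n2)cc1`) gives 1430 nM in this assay; these two values lie within the usual scatter of each other, so no order between them is claimed.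

The unmeasured compound 4 (`Cc1cnc(Nc2ccc(S(N)(=O)=O)cc2)nc1Nc1nc2ccccc2s1`) keeps the core of compound 1 and differs from it in one place: sulfamoyl in place of isopropyl on an aromatic carbon. That is, sulfamoyl in place of isopropyl on an aromatic carbon. Going by the values given here, no measured pair shows this exact change, so the size of the step rests on the contrast between compound 1 at its limit and the sulfonyl-bearing compounds 2 and 3. On that basis compound 4 is expected to be a considerably stronger inhibitor than compound 1, a step of an at least 14-fold lower number from compound 1 to compound 4 (1.15 log units; beyond the scatter) in this assay. For compound 4 the estimated value in this assay is 3500 nM, with a range from 900 nM to 15000 nM.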

Compound 4, half-maximal inhibitory concentration: > 50000 nM
Compound 4: a limit, no number; the forecaster's own chance of this, stated with the estimate: 10%; at least 14-fold (1.15 log units) between middle value and limit.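

In this assay compound 4 gives > 50000 nM, a limit and not a number. Compound 1 and compound 4 thus both stand at a limit, so no step between them can be read: the limit of > 50000 nM in this assay, at which 2 of the 4 values shown sit.

The compounds shown leave open whether sulfamoyl in place of isopropyl on an aromatic carbon changes the value at all.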